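The source may report more compounds than this note shows. Statements on the series, on what has been measured and on what is new or still open speak of the compounds shown alone.

Measured compounds: compound 1 `O=S(=O)(NC1CCN(S(=O)(=O)c2ccccc2)CC1)c1cc(S(=O)(=O)c2ccccc2)ccc1C(F)(F)F`, compound 2 `N#Cc1cccc(S(=O)(=O)N2CCC(NS(=O)(=O)c3cc(S(=O)(=O)c4ccccc4)ccc3C(F)(F)F)CC2)c1` and compound 3 `CC(C)(C)OC(=O)N1CCC(C(=O)N2CCC(NS(=O)(=O)c3cc(S(=O)(=O)c4ccccc4)ccc3C(F)(F)F)CC2)CC1`. In a physicochemical assay for solubility (on this read-out lower numbers stand for lower solubility and higher numbers for higher solubility), compound 1 gives 25000 nM, compound 2 gives 6300 nM and compound 3 gives 25000 nM.

Compound 1 stands level with compound 3 at these digits, the two together giving the highest numbers of the three, while compound 2 sits lowest: a 4.0-fold lower number from compound 1 to compound 2 (0.60 log units; beyond the scatter). The unmeasured compound 4 `O=C([C@@H]1CCNC1)N1CCC(NS(=O)(=O)c2cc(S(=O)(=O)c3ccccc3)ccc2C(F)(F)F)CC1` differs from compound 1 in one place: (pyrrolidin-3-yl)carbonyl in place of phenylsulfonyl on an amine nitrogen in a ring. Within the data shown here, the only measured step, the cyano change from compound 1 to compound 2, touches a different part of the molecule and does not bear on this exchange. Compounds 1 and 3 show the same number, so a step of no size beyond the scatter is expected in this assay, and compound 4 is estimated at 30000 nM (range 12000 nM to 75000 nM), meaning an expected 1.2-fold higher number from compound 1 to compound 4 (0.08 log units; within the scatter).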

Compound 4, solubility: 12500 nM
Compound 4: middle estimate off by 2.4-fold (0.38 log units), on the high side; the range from low to high includes it.
By their numbers in this assay, from the lowest: compounds 2, 4, 1 and 3 (each within the scatter of the next, the first and the last beyond it).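

Putting (pyrrolidin-3-yl)carbonyl in place of phenylsulfonyl on the amine nitrogen in the ring gives a 2.0-fold lower number from compound 1 to compound 4 (0.30 log units; within the scatter) in this assay and shows that a sulfonyl-linked aromatic ring is not required at this position for a number within the scatter. In place of (3-cyanophenyl)sulfonyl, the same group gives a 2.0-fold higher number from compound 2 to compound 4 (0.30 log units; within the scatter) so the new compound lies within the scatter of two compounds that are themselves beyond it. No measured evidence explains these results. Still open, from the compounds shown here alone, is how a carboxylic acid or an open-chain amine at this nitrogen would read, and how the opposite stereocentre of the pyrrolidine would compare.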